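The source may report more compounds than this note shows. Statements on the series, on what has been measured and on what is new or still open speak of the compounds shown alone.

Compounds measured so far:
compound 1, `O=C(CSc1nnnn1-c1ccccc1)N/N=c1/scc(-c2ccc(Cl)cc2)n1-c1ccccc1`, 313 ug/mL in an ADME assay on NIH3T3 cells (Mus musculus) for cytotoxicity, read by MTT assay, with a stated time of 24 h; on this read-out higher numbers stand for weaker inhibition and lower numbers for stronger inhibition;
compound 2, `Cn1cnnc1SCC(=O)N/N=c1/scc(-c2ccc(F)cc2)n1-c1ccccc1`, 65 ug/mL.

Compound 2 gives the lower of the two numbers; compound 1 sits beyond the scatter from it. Compound 3, `Cn1cnnc1SCC(=O)N/N=c1/scc(-c2ccc(Cl)cc2)n1-c1ccccc1`, has not been measured. It differs from compound 2 only in this way: chloro in place of fluoro on an aromatic carbon. Among the compounds with values here, no step between measured compounds matches that change, so the direction it takes in this assay is unknown. The step from compound 2 to compound 3 is expected to be small, and no change beyond the scatter is expected, as a 1.4-fold higher number from compound 2 to compound 3 (0.14 log units; within the scatter). Compound 3 is accordingly estimated at 90 ug/mL, within a range from 35 ug/mL to 250 ug/mL.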

Compound 3, half-maximal inhibitory concentration: 51.7 ug/mL
Estimate against measurement, compound 3: 1.7-fold (0.24 log units) above; the measured number falls inside the stated range.
By their numbers in this assay, from the lowest: compounds 3 and 2 (each within the scatter of the next); then compound 1.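

In this assay, chloro in place of fluoro on the aromatic carbon gives a 1.3-fold lower number from compound 2 to compound 3 (0.10 log units; within the scatter), so this halogen change leaves the number within the scatter. With the 4-chlorophenyl kept, 4-methyl-4H-1,2,4-triazol-3-yl in place of 1-phenyl-1H-tetrazol-5-yl on the sulfur gives a 6.1-fold lower number from compound 1 to compound 3 (0.78 log units; beyond the scatter), a step beyond the scatter. Nothing available explains either step. Going by these compounds, whether an amine or a methoxy group in place of the halogen would stay as close remains open. So does what a longer chain in place of the methyl would do.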